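Shortening the enoyl chain on the amide of compound 1

The source may report more compounds than this note shows. Statements on the series, on what has been measured and on what is new or still open speak of the compounds shown alone.

Among the compounds with values here, compound 1 `CCC/C=C/C(=O)N(Cc1ccc(OC)c(O)c1)c1cc(OC)c(OC)c(OC)c1` gives 70 nM in a functional assay on MGC-803 cells (Homo sapiens) for inhibition, read by MTT assay, with a stated time of 48 h (on this read-out lower numbers stand for stronger inhibition and higher numbers for weaker inhibition), the lowest number among the three measured members. Within the data shown here, compound 2 `C/C=C/C(=O)N(Cc1cc(OC)c(OC)c(OC)c1)c1ccc(OC)c(O)c1` gives 6150 nM in this assay, and compound 3 `COc1cc(NCc2cccc(O)c2)cc(OC)c1OC` gives 57600 nM; both gaps from compound 1 lie beyond the scatter, but each of these two differs from compound 1 in more than one place, so no single step is isolated. Compound 4 `CC/C=C/C(=O)N(Cc1ccc(OC)c(O)c1)c1cc(OC)c(OC)c(OC)c1` is the next member. Its difference from compound 1: hydrogen in place of methyl on a saturated chain carbon, two bonds along the chain from a double-bonded chain carbon. Among the measured compounds shown here, no step of this kind has been measured. Only one carbon of the chain leaves, so a small weakening, or none beyond the scatter, is expected. The expected step in this assay is a 1.7-fold higher number from compound 1 to compound 4 (0.23 log units; within the scatter). Compound 4 is estimated at 120 nM, within a range of 40 nM to 400 nM.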

Compound 4, half-maximal inhibitory concentration: 58 nM
Estimate against measurement, compound 4: 2.1-fold (0.32 log units) above, and the stated range covers the measured number.
By their numbers in this assay, from the lowest: compounds 4 and 1 (each within the scatter of the next); then compound 2; then compound 3.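

In this assay, the change from pent-1-en-1-yl to but-1-en-1-yl gives a 1.2-fold lower number from compound 1 to compound 4 (0.08 log units; within the scatter), so this methyl can give way to hydrogen without a step beyond the scatter. Within the data shown here, this is the first step confined to one place, and it concerns only this chain carbon. Nothing on hand gives a reason for the result.

Still open, on these data alone, is whether a longer chain in place of pent-1-en-1-yl keeps the number in this range. Also open, as far as these compounds go, is how an amine or a carboxylic acid in place of this methyl would read in this assay.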